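The source may report more compounds than this note shows. Statements on the series, on what has been measured and on what is new or still open speak of the compounds shown alone.

Measured compounds:
Compound 1, `Brc1ccccc1Nc1nc2cccnc2[se]1`, gives in a functional assay on MCF7 cells (Homo sapiens) for cytotoxicity, read by MTT assay, with a stated time of 72 h (on this read-out lower numbers stand for stronger inhibition and higher numbers for weaker inhibition), a value of 185000 nM.
Compound 2, `Cc1ccccc1Nc1nc2cccnc2[se]1`, gives in this assay a value of 52500 nM.
Compound 3, `Cc1ccc(Nc2nc3cccnc3[se]2)cc1`, gives in this assay a value of 91500 nM.

Among these three, compound 2 has the lowest number. Its gap to compound 3 lies within the scatter, so the two cannot be put in order; its gap to compound 1 is beyond the scatter, shown by the step of a 3.5-fold lower number from compound 1 to compound 2 (0.55 log units; beyond the scatter), which brought a methyl in place of a bromo on an aromatic carbon.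

Compound 4, `Clc1ccccc1Nc1nc2cccnc2[se]1`, has not yet been measured in this assay. It differs from compound 2 in one place: chloro in place of methyl on an aromatic carbon, a chloro in place of a methyl on an aromatic carbon of a six-membered aromatic ring of carbon only, ortho to a large group. Among the compounds with values here, the only measured step that bears on this is the one from bromo to methyl between compound 1 and compound 2, a modest step. Chloro and bromo are both halogens, so the reverse change, methyl to chloro, is expected to move the number back upward, though by less than the full bromo-to-methyl step, because a 3.5-fold lower number from compound 1 to compound 2 (0.55 log units; beyond the scatter) concerned a different halogen. Compound 4 is therefore estimated at 100000 nM, with a range from 45000 nM to 230000 nM, a step of a 1.9-fold higher number from compound 2 to compound 4 (0.28 log units; within the scatter).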

Compound 4, half-maximal inhibitory concentration: 43300 nM
Beside the measured number, compound 4's estimate is 2.3-fold (0.36 log units) above it, and the stated range ends above it.
By their numbers in this assay, from the lowest: compounds 4, 2 and 3 (each within the scatter of the next, the first and the last beyond it); then compound 1.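

At this place, on an aromatic carbon of a six-membered aromatic ring of carbon only, ortho to a large group, the halogen as such does not decide the outcome in this assay: chloro in place of methyl gives a 1.2-fold lower number from compound 2 to compound 4 (0.08 log units; within the scatter), so these two groups cannot be told apart here. Chloro in place of bromo gives a 4.3-fold lower number from compound 1 to compound 4 (0.63 log units; beyond the scatter), which shows that the earlier bromo-to-methyl difference does not extend to chloro, and that among compounds 1, 2 and 4 bromo alone stands apart, with no compound among the three going against this. Nothing in the data shown accounts for this difference between the two halogens.

The compounds shown leave open whether fluoro, methoxy, an amine or a carboxylic acid at this place would fall with chloro and methyl or with bromo. They also leave open whether the separation of bromo from chloro would hold on another core or in any other test, as all of these values come from a single read-out on one shared core.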